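This account rests on a few compounds, and the source may have more. Where it says the series, first, only, none or still open, it means among the compounds named here.

Compound 1 `CCCSc1nc2nc(C)cc(N3CC[C@@H](C)[C@@H](N(C)c4ncnc5[nH]ccc45)C3)n2n1` was tested in a toxicity assay on GES1 cells (Homo sapiens) for inhibition, read by MTT assay, with a stated time of 72 h (a higher number here means a weaker inhibitor, a lower number a stronger inhibitor), where compound 1 gives 67100 nM. Of the two plain numbers in this small set, compound 1 stands at the higher, but its nearest neighbour, compound 3 `Cc1cc(N2CC[C@@H](C)[C@@H](N(C)c3ncnc4[nH]ccc34)C2)n2nc(SCc3ccc(Br)cc3)nc2n1`, gives 55600 nM, and the gap is only a 1.2-fold lower number from compound 1 to compound 3 (0.08 log units; within the scatter). Compound 2 `C=CCSc1nc2nc(C)cc(N3CC[C@@H](C)[C@@H](N(C)c4ncnc5[nH]ccc45)C3)n2n1` reaches the upper edge of the assay, recorded as > 100000 nM, which is a limit and not a number (the limit of > 100000 nM in this assay, at which 1 of the 3 values shown sits). The comparisons an at least 1.4-fold higher number from compound 1 to compound 2 (0.17 log units; that floor lies within the scatter) and an at least 1.7-fold lower number from compound 2 to compound 3 (0.25 log units; that floor lies within the scatter) therefore rest on that limit and say little.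

Compound 4 `Cc1cc(N2CC[C@@H](C)[C@@H](N(C)c3ncnc4[nH]ccc34)C2)n2nc(SCc3ccc([N+](=O)[O-])cc3)nc2n1` differs from compound 1 by 4-nitrophenyl in place of ethyl on a saturated chain carbon bound to a sulfur. Within the data shown here, the one measured step that bears on this, from compound 1 to compound 3, placed a different substituted phenyl at the same chain carbon and stayed within the scatter. The step expected here is therefore a 1.1-fold lower number from compound 1 to compound 4 (0.05 log units; within the scatter), with nothing beyond the scatter. For compound 4 the estimate in this assay is 60000 nM, expected to fall between 25000 nM and 140000 nM.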

Compound 4, half-maximal inhibitory concentration: 36600 nM
Compound 4: middle estimate off by 1.6-fold (0.21 log units), on the high side, and the stated range covers the measured number.
By their numbers in this assay, from the lowest: compounds 4, 3 and 1 (each within the scatter of the next). At a limit, above all of these: compound 2.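

Two substituted benzyl groups have now been tried on this sulfur, and in this assay the change from propyl to 4-nitrobenzyl again stays within the scatter, with a 1.8-fold lower number from compound 1 to compound 4 (0.26 log units; within the scatter) on record. Changing only the substituent on the ring, nitro in place of bromo on an aromatic carbon, gives a 1.5-fold lower number from compound 3 to compound 4 (0.18 log units; within the scatter), so this pair shows no difference that can be told from the scatter. Among these compounds, the first step beyond the scatter in this set, an at least 2.7-fold lower number from compound 2 to compound 4 (0.43 log units; beyond the scatter), has 4-nitrophenyl in place of vinyl, but it starts from a limit and not from a number: the limit of > 100000 nM in this assay, at which 1 of the 4 values shown sits.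

On these data alone, whether an amine or a carboxylic acid on the benzyl ring, or a longer chain on the sulfur, would move the number beyond the scatter stays open. As far as these compounds go, how far compound 2 lies past its limit also stays open.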